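The source may hold more compounds than are shown below. What is called first, only, known or untested is meant among the compounds shown, and "the series" means these compounds.

Compound 1, `CCCCCOC(=O)Cc1c(C(C)C)nc(CCCC)n(Cc2ccc(-c3ccccc3-c3noc(=O)[nH]3)cc2)c1=O`, is the starting point of this account. Within the data shown here, in an ADME assay on microsomes from liver (Homo sapiens) for metabolic stability, with a stated time of 30 min (a lower number here means that less of the compound is left, a higher number that more of the compound is left), compound 1 gives 10.6%, which places it second highest of the three numbers measured so far. Its nearest neighbour is compound 2, `CCCCc1nc(C(C)C)c(CC(=O)OC2CC2)c(=O)n1Cc1ccc(-c2ccccc2-c2noc(=O)[nH]2)cc1`, which gives 10.3% in this assay; the step from compound 1 to compound 2, a number 0.3 percentage points lower from compound 1 to compound 2 (within the scatter), is within the scatter. Compound 3, `CCCCc1nc(C(C)C)c(CC(=O)OC2CCCCC2)c(=O)n1Cc1ccc(-c2ccccc2-c2noc(=O)[nH]2)cc1`, gives 13.3% in this assay, and the step of a number 2.7 percentage points higher from compound 1 to compound 3 (within the scatter) is likewise within the scatter, as is a number 3 percentage points higher from compound 2 to compound 3 (within the scatter).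

Compound 4, `CCCCc1nc(C(C)C)c(CC(=O)OC(CC)CC)c(=O)n1Cc1ccc(-c2ccccc2-c2noc(=O)[nH]2)cc1`, has the same atoms as compound 1, joined differently: pentan-3-yl in place of pentyl on an oxygen next to a carbonyl group. Read one bond further out, pentyloxy becomes (pentan-3-yl)oxy.

The three measured steps all exchange the group on that same oxygen next to a carbonyl group, among pentyl, cyclopropyl and cyclohexyl, and none of them moved this assay beyond the scatter. On that basis the exchange of pentyl for pentan-3-yl at the same place is expected to give no step beyond the scatter either, in no particular direction, so that a number 0.4 percentage points higher from compound 1 to compound 4 (within the scatter) is the expected step. Compound 4 is therefore estimated at 11% in this assay, within a range of 4% to 22%.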

Compound 4, percent of the compound remaining: 7.7%
For compound 4 the middle estimate is 3.3 percentage points above the measured one; the measured number falls inside the stated range.
By their numbers in this assay, from the lowest: compounds 4, 2, 1 and 3 (each within the scatter of the next).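

In this assay, rejoining the atoms of pentyl as pentan-3-yl on the oxygen next to a carbonyl group gives a number 2.9 percentage points lower from compound 1 to compound 4 (within the scatter). This adds a change of a different kind to the earlier exchanges at this place: the same atoms in a different arrangement, rather than a group with a ring in place of an open chain or one ring in place of another. Pentan-3-yl also stands within the scatter of both groups with a ring, with a number 5.6 percentage points lower from compound 3 to compound 4 (within the scatter) and a number 2.6 percentage points lower from compound 2 to compound 4 (within the scatter), so all four groups shown on this oxygen give numbers that cannot be told apart, and nothing available bears on why they lie where they do.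

Going by these compounds, whether tert-butyl on this oxygen, or an amide or a carboxylic acid in place of the whole oxygen-bearing group, would give a step beyond the scatter remains open. Because all four compounds differ only at this place, the compounds shown also leave open what a change elsewhere on the shared core would do in this assay.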